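The source may report more compounds than this note shows. Statements on the series, on what has been measured and on what is new or still open speak of the compounds shown alone.

The shared core appears first in compound 1 `c1ccc(CSc2nc3cnsc3[nH]2)cc1`, which in a functional assay on HFF cells (Homo sapiens) for inhibition (on this read-out lower numbers stand for stronger inhibition and higher numbers for weaker inhibition), gives 14000 nM. Compound 2 `CSc1nc2cnsc2n1[C@H]1C[C@H](O)[C@@H](CO)O1` reaches only a limit in this assay, > 100000 nM. Compound 3 `Cc1nsc2c1nc(SCc1ccccc1)n2[C@H]1C[C@H](O)[C@@H](CO)O1` likewise reaches only a limit, > 100000 nM, so compound 3 stands at the limit of > 100000 nM in this assay, at which 2 of the 3 values shown sit. Compound 4 `OC[C@H]1O[C@@H](n2c(SCc3ccccc3)nc3cnsc32)C[C@@H]1O` differs from compound 3 by hydrogen in place of methyl on an aromatic carbon. For the measured compounds named here, no measured pair isolates this change, so its size is unknown; among the three numbers only compound 1 yields a value inside the measurable range. Compound 4 is therefore expected to remain weak, and the step of an at least 1.6-fold lower number from compound 3 to compound 4 (0.22 log units; that floor lies within the scatter) is expected to be small, not clearly beyond the scatter. The estimate for compound 4 is 60000 nM, within a range of 15000 nM to 150000 nM.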

Compound 4, half-maximal inhibitory concentration: > 100000 nM
Compound 4: no number, only a limit; the forecaster's own chance of this, stated with the estimate: 55%; middle value at least 1.6-fold (0.22 log units) from the limit.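

For the compounds shown here, the step to compound 4 gives the first readable single change in this assay: with 4-hydroxy-5-(hydroxymethyl)oxolan-2-yl in place of hydrogen on an aromatic nitrogen, the result is an at least 7.1-fold higher number from compound 1 to compound 4 (0.85 log units; beyond the scatter). Hydrogen in place of methyl on the aromatic carbon leaves the value at a limit, and the steps to compound 4 from compound 2 and compound 3 cannot be read. The limit is now shared by three compounds: the limit of > 100000 nM in this assay, at which 3 of the 4 values shown sit.

Going by these compounds, it remains open whether an amine on that aromatic carbon would give a value inside the measurable range. On these data alone, it is equally open how a carboxylic acid on the oxolane ring would read.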